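Cytotoxicity of a urea series: swapping the lactam substituent

A few compounds are considered here, and "the series" means these few. Any claim that something is new, unique, unknown or untested is made for them only; others in the source may bear on it.

Measured so far:
- compound 1, `O=C(Nc1cc(F)c(F)c(F)c1)N1Cc2c(-c3ccc(F)cc3F)cnn2CC1C1CC1`: 32100 nM
- compound 2, `N#CC1CC(=O)N(c2cnn3c2CN(C(=O)Nc2cc(F)c(F)c(F)c2)C(C2CC2)C3)C1`: > 200000 nM
- compound 3, `O=C1CC(Oc2ncc(F)cn2)CN1c1cnn2c1CN(C(=O)Nc1cc(F)c(F)c(F)c1)C(C1CC1)C2`: 96200 nM

The read-out is a toxicity assay on HepG2 2.2.15 cells (Homo sapiens) for cytotoxicity, read by CellTiter-Glo; a lower number here means that less compound is tolerated, a higher number that more compound is tolerated. Compound 2 reaches only the limit of the assay, > 200000 nM, and gives no number (the limit of > 200000 nM in this assay, at which 1 of the 3 values shown sits). Among the two numbers, compound 3 stands highest, above compound 1, a gap beyond the scatter.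

The step to compound 4, `O=C1CC(c2ccccc2)CN1c1cnn2c1CN(C(=O)Nc1cc(F)c(F)c(F)c1)C(C1CC1)C2`, changes (phenyl in place of (5-fluoropyrimidin-2-yl)oxy on a saturated ring carbon). Among the compounds with values here, two measured steps touch this part of the molecule: an at least 6.2-fold higher number from compound 1 to compound 2 (0.79 log units; beyond the scatter) and an at least 2.0-fold lower number from compound 2 to compound 3 (0.31 log units; beyond the scatter). Both show that what sits on this ring can move the number by a modest amount in either direction. Replacing (5-fluoropyrimidin-2-yl)oxy by phenyl is a comparable change, so a modest step is expected, downward toward compound 1, though the direction is uncertain. Compound 4 is therefore estimated at 50000 nM, within 20000 nM to 150000 nM, an expected step of a 1.9-fold lower number from compound 3 to compound 4 (0.28 log units; within the scatter).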

Compound 4, half-maximal cytotoxic concentration: 12800 nM
The estimate for compound 4 lay 3.9-fold (0.59 log units) above the measured number; measured number below the stated range.
By their numbers in this assay, from the lowest: compound 4; then compound 1; then compound 3. At a limit, above all of these: compound 2.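

In this assay, the saturated ring carbon of the five-membered ring tells two aromatic rings apart, with phenyl in place of (5-fluoropyrimidin-2-yl)oxy giving a 7.5-fold lower number from compound 3 to compound 4 (0.88 log units; beyond the scatter). The earlier compounds shown here suggested that this ring raises the number relative to 2,4-difluorophenyl, but with phenyl on it the order reverses, with a 2.5-fold lower number from compound 1 to compound 4 (0.40 log units; beyond the scatter). Against the nitrile the drop is the largest step here, an at least 15-fold lower number from compound 2 to compound 4 (1.19 log units; beyond the scatter), and its true size is unknown, since compound 2 stands at a limit: the limit of > 200000 nM in this assay, at which 1 of the 4 values shown sits.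

Phenyl removes the linking oxygen and the ring nitrogens together, and the compounds shown do not tell which of these matters. On these data alone, how an amine or a carboxylic acid on this carbon would read also stays open.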